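This account rests on a few compounds, and the source may have more. Where it says the series, first, only, none or still open, it means among the compounds named here.

In a functional assay on MOLT-4 cells (Homo sapiens) for antiproliferative activity, with a stated time of 48 h (on this read-out lower numbers stand for stronger inhibition and higher numbers for weaker inhibition), compound 1, `C=C(Br)C(=O)Nc1ccc(/C=C/C(=O)c2ccccc2)cc1`, gives 3100 nM, while compound 2, `C=C(Br)C(=O)Nc1ccc(/C=C/C(=O)c2cccc(OC)c2)cc1`, gives 850 nM. The step of a 3.6-fold lower number from compound 1 to compound 2 (0.56 log units; beyond the scatter) goes with the change (methoxy in place of hydrogen on an aromatic carbon). Compound 3, `COc1cccc(/C=C/C(=O)c2ccc(N)cc2)c1`, gives 21000 nM in this assay, the highest of the three numbers; the difference between the core of compound 3 and the core of compound 1 is not broken down here. Compound 4, `COc1cc(/C=C/C(=O)c2ccc(N)cc2)cc(OC)c1`, has not yet been measured. It differs from compound 3 by methoxy in place of hydrogen on an aromatic carbon, which is the same kind of change as that from compound 1 to compound 2, though here the place is also meta to a methoxy group. On the strength of the step of a 3.6-fold lower number from compound 1 to compound 2 (0.56 log units; beyond the scatter), a step of similar, modest size is expected, namely a 3.0-fold lower number from compound 3 to compound 4 (0.48 log units; beyond the scatter). Compound 4 is therefore expected to give about 7000 nM in this assay, most likely between 2500 nM and 20000 nM.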

Compound 4, half-maximal inhibitory concentration: 7500 nM
Compound 4: the middle estimate sits 1.1-fold (0.03 log units) below what was measured; measured number inside the range.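

In this assay, methoxy in place of hydrogen on an aromatic carbon gives a 2.8-fold lower number from compound 3 to compound 4 (0.45 log units; beyond the scatter), and this step closely matches the earlier one on the other core: the same change on two cores in this assay, a 3.6-fold lower number (0.56 log units; beyond the scatter) from compound 1 to compound 2 and a 2.8-fold lower number (0.45 log units; beyond the scatter) from compound 3 to compound 4, 1.3-fold (0.11 log units) apart, within the scatter of two such steps. In these two pairs, then, the change carries over from one core to the other at much the same modest size. Going by these compounds alone, this rests on only two pairs, however, and in compound 4 the new methoxy is also meta to a methoxy group, so it does not show that the step would hold on other cores or at other places.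

The compounds shown leave open whether an ethoxy group or a hydroxyl group at the same place would give a similar step. Also open, going by these compounds, is what a second methoxy group would do on the core of compound 1.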